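A carboxyethylamino group added to compound 1

This account rests on a few compounds, and the source may have more. Where it says the series, first, only, none or still open, it means among the compounds named here.

Going by the values given here, in a physicochemical assay for lipophilicity, read by HPLC, at pH 7.5 (on this read-out higher numbers stand for higher lipophilicity and lower numbers for lower lipophilicity), compound 1 (`CCOc1ccccc1-c1ccc(-c2nc3cnccc3cc2C#N)cc1`) gives 3.8 as the higher of the two numbers measured so far, while compound 2 (`CC[C@@H](Nc1c(C#N)c(-c2ccc(-c3ccccc3F)cc2)nc2cnccc12)C(N)=O`) gives 2.7 and stands lower, beyond the scatter. Compound 3 (`CCOc1ccccc1-c1ccc(-c2nc3cnccc3c(NC(C)C(=O)O)c2C#N)cc1`) carries (1-carboxyethyl)amino in place of hydrogen on an aromatic carbon, ortho to a cyano group and opposite the ring nitrogen. Among the compounds with values here, no measured step covers this change, so the expectation in this assay rests on the structural change alone. The expected step is a number 2.60 log units lower from compound 1 to compound 3 (beyond the scatter) (a large fall, well beyond the scatter). Compound 3 is estimated at 1.2 (range 0.4 to 2).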

Compound 3, distribution coefficient: 2.1
Estimate against measurement, compound 3: 0.90 log units below, and the stated range ends below it.
By their numbers in this assay, from the lowest: compound 3; then compound 2; then compound 1.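

Going by these compounds alone, the first single-place step in this set shows that this assay responds strongly at the position opposite the ring nitrogen: (1-carboxyethyl)amino in place of hydrogen there gives a number 1.70 log units lower from compound 1 to compound 3 (beyond the scatter). Compound 2 differs from compound 1 in more than one place, so it could not show this. Nothing in the data accounts for the size of this step. From the compounds shown here alone, whether the fall belongs to the whole chain or to one part of it remains open. A plain amino group or a methyl ester at this position would separate the two.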